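The source may hold more compounds than are shown below. What is called first, only, known or untested is meant among the compounds shown, and "the series" means these compounds.

Working notes on the series, all read in a functional assay on PC-3 cells (Homo sapiens) for inhibition, read by sulforhodamine B assay, with a stated time of 48 h, tested at 50 uM (on this read-out higher numbers stand for more inhibition of growth at the one concentration tested and lower numbers for less inhibition of growth), as the only test so far. Compound 2 (`C#CCO/N=C1/C[C@@H](c2ccc(OC)cc2)Oc2cc(OC)c(CC=C(C)C)cc21`) gives 41% and compound 1 (`COc1ccc([C@@H]2C/C(=N/OCc3cn(-c4cc(OC)c(OC)c(OC)c4)nn3)c3cc(CC=C(C)C)c(OC)cc3O2)cc1`) gives 36% in the same test. Going by the values given here, these are the only two numbers available and they lie within the scatter of each other, so compound 2 stands level with compound 1 and neither can be ranked.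

Next comes compound 3 (`COc1ccc([C@@H]2C/C(=N/OCc3cn(-c4cccnc4Cl)nn3)c3cc(CC=C(C)C)c(OC)cc3O2)cc1`), which has no measurement yet. The structural change from compound 2 to compound 3 is large in counted terms (1-(2-chloropyridin-3-yl)-1H-1,2,3-triazol-4-yl in place of ethynyl on a saturated chain carbon bound to an oxygen on an unsaturated carbon): the small ethynyl gives way to the much bulkier 1-(2-chloropyridin-3-yl)-1H-1,2,3-triazol-4-yl.

Among the compounds with values here, no measured pair differing in one place exists, so any expectation rests on little. Within the data shown here, with compound 1 at 36% and compound 2 at 41% as the only guide, no step beyond the scatter is expected in this assay and neither direction is favoured. The estimated change runs a number 4 percentage points lower from compound 2 to compound 3 (within the scatter) and stays within that scatter. Compound 3 is expected at 37% with an estimated range from 22% to 52% as the upper end.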

Compound 3, percent growth inhibition at one concentration: 44%
Compound 3: the middle estimate sits 7 percentage points below what was measured; the range from low to high includes it.
By their numbers in this assay, from the lowest: compounds 1, 2 and 3 (each within the scatter of the next).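

In this assay, 1-(2-chloropyridin-3-yl)-1H-1,2,3-triazol-4-yl in place of ethynyl on a saturated chain carbon bound to an oxygen on an unsaturated carbon gives a number 3 percentage points higher from compound 2 to compound 3 (within the scatter), so this place holds a group with two aromatic rings as well as the small ethynyl with the read-out staying level. Going by these compounds alone, the first comparison of substituents on an aromatic nitrogen, 2-chloropyridin-3-yl in place of 3,4,5-trimethoxyphenyl, gives a number 8 percentage points higher from compound 1 to compound 3 (within the scatter), so these two groups cannot be told apart here, and the three compounds show no ranking. Nothing in hand explains this flat picture.

The compounds shown leave open whether any group at this place moves the read-out beyond the scatter, for instance a saturated chain such as propyl, or an aminomethyl group in place of ethynyl. On these data alone, it also remains open whether an unsubstituted phenyl, or a phenyl carrying a carboxylic acid, on the aromatic nitrogen would separate from the 2-chloropyridin-3-yl of compound 3.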